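This account rests on a few compounds, and the source may have more. Where it says the series, first, only, none or still open, it means among the compounds named here.

Measured compounds:
compound 1 `O=C(O)c1cccc(Cc2c(-c3ccccc3)nn3ccccc23)n1` with 2300 nM
compound 2 `CS(=O)(=O)c1ccc2c(Cc3cccc(C(=O)O)n3)c(-c3ccccc3)nn2c1` with 5400 nM
compound 3 `O=C(O)c1cccc(Cc2c(-c3cccs3)nn3cc(Cl)ccc23)n1` with 1100 nM

In a functional assay on cells for antagonist activity at prostaglandin E2 receptor EP1 subtype (Rattus norvegicus), read by fluorescence and calcium flux, with a stated time of 60 s (on this read-out lower numbers stand for stronger inhibition and higher numbers for weaker inhibition), compound 3 gives the lowest number of the three, so it is the strongest inhibitor among the measured compounds; compound 1 gives 2300 nM and compound 2 gives 5400 nM, both higher numbers. For the measured compounds named here, the only single-point step among the measured compounds, a 2.3-fold higher number from compound 1 to compound 2 (0.37 log units; beyond the scatter), concerns a methylsulfonyl group added on the fused core and says nothing about the aryl group that is changed here.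

Compound 4 `O=C(O)c1cccc(Cc2c(N3CCCC3)nn3cc(Cl)ccc23)n1` is not yet measured. It differs from compound 3 in one place: pyrrolidin-1-yl in place of thiophen-2-yl on an aromatic carbon. Going by the values given here, no measured pair shows what happens when the aromatic ring in that place gives way to a saturated ring, so the expectation rests on the range of the three values alone. The step from compound 3 to compound 4 is expected to be a 3.2-fold higher number from compound 3 to compound 4 (0.50 log units; beyond the scatter), a weakening of modest size. Compound 4 is therefore estimated at 3500 nM in this assay, within a range from 800 nM to 15000 nM.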

Compound 4, half-maximal inhibitory concentration: 1800 nM
For compound 4 the middle estimate is 1.9-fold (0.29 log units) above the measured one, within the range that was stated.
By their numbers in this assay, from the lowest: compounds 3, 4 and 1 (each within the scatter of the next, the first and the last beyond it); then compound 2.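

In this assay, putting pyrrolidin-1-yl in place of thiophen-2-yl on an aromatic carbon of the five-membered aromatic ring with 2 nitrogen gives a 1.6-fold higher number from compound 3 to compound 4 (0.21 log units; within the scatter) and so no difference that can be told apart. For the compounds shown here, compounds 1, 2 and 3 all carry an aromatic ring in this place, so compound 4 is the first to show that, for this pair, a non-aromatic ring with the same count of heavy atoms can stand here without a change beyond the scatter. Nothing measured here explains why the read-out holds across this change.

Going by these compounds, whether an open-chain amine such as dimethylamino, or a six-membered ring such as morpholin-4-yl, would fit this place as well remains open. On these data alone, it is also open whether pyrrolidin-1-yl would behave the same way on a core without the chlorine of compound 4.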